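The source may hold more compounds than are shown below. What is called first, only, known or untested is meant among the compounds shown, and "the series" means these compounds.

Working notes on a small set of triphosphate analogues built on the core of compound 1 `O=c1[nH]/c(=N\OCCOc2ccccc2)ccn1[C@@H]1O[C@H](COP(=O)(O)OP(=O)(O)OP(=O)(O)O)[C@@H](O)[C@H]1O`, which in a functional assay on 1321-N1 cells for agonist activity at P2Y purinoceptor 4 (Homo sapiens), read by scintillation counting and inositol phosphate accumulation (on this read-out lower numbers stand for an effect already at smaller amounts and higher numbers for an effect only at larger amounts of compound), gives 430 nM. Compound 2 `O=c1[nH]/c(=N\OCCCc2cccc([N+](=O)[O-])c2)ccn1[C@@H]1O[C@H](COP(=O)(O)OP(=O)(O)OP(=O)(O)O)[C@@H](O)[C@H]1O` gives 95 nM in this assay, and compound 3 `O=c1[nH]/c(=N\OCCCc2ccncc2)ccn1[C@@H]1O[C@H](COP(=O)(O)OP(=O)(O)OP(=O)(O)O)[C@@H](O)[C@H]1O` gives 250 nM. Among the three numbers compound 3 stands second highest; the step of a 1.7-fold lower number from compound 1 to compound 3 (0.24 log units; within the scatter) is within the scatter, whereas a 2.6-fold higher number from compound 2 to compound 3 (0.42 log units; beyond the scatter) and a 4.5-fold lower number from compound 1 to compound 2 (0.66 log units; beyond the scatter) both lie beyond it. Compound 4 `O=c1[nH]/c(=N\OCCCc2ccsc2)ccn1[C@@H]1O[C@H](COP(=O)(O)OP(=O)(O)OP(=O)(O)O)[C@@H](O)[C@H]1O` is not yet measured and differs from compound 3 as follows: thiophen-3-yl in place of pyridin-4-yl on a saturated chain carbon, three bonds along the chain from an oxygen. Among the measured compounds shown here, no measured step exchanges one aromatic ring for another of a different ring size at this place. What bears on it is that the step of a 2.6-fold higher number from compound 2 to compound 3 (0.42 log units; beyond the scatter) shows a change of the ring at this place can move the number beyond the scatter, while the step of a 1.7-fold lower number from compound 1 to compound 3 (0.24 log units; within the scatter) shows a change at this place can also stay within it. For compound 4 the expected step is therefore small, a 1.3-fold lower number from compound 3 to compound 4 (0.10 log units; within the scatter), if anything toward a lower number. Compound 4 is estimated at 200 nM, with a range of 80 nM to 500 nM.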

Compound 4, half-maximal effective concentration: 20 nM
Compound 4: the middle estimate sits 10-fold (1.00 log units) above what was measured, and the stated range ends above it.
By their numbers in this assay, from the lowest: compound 4; then compound 2; then compounds 3 and 1 (each within the scatter of the next).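

In this assay, exchanging the ring on a saturated chain carbon, three bonds along the chain from an oxygen, gives a 13-fold lower number from compound 3 to compound 4 (1.10 log units; beyond the scatter) and so makes a larger step than any among compound 1, compound 2 and compound 3. The same thiophen-3-yl group also gives a 4.8-fold lower number from compound 2 to compound 4 (0.68 log units; beyond the scatter) and a 22-fold lower number from compound 1 to compound 4 (1.33 log units; beyond the scatter) and so puts compound 4 lowest of the four, with all its steps beyond the scatter. Among the compounds shown here, nothing available explains why this ring exchange moves the number so far.

The compounds shown leave open whether the step follows the sulfur atom, the five-membered ring or the point of attachment; thiophen-2-yl, furan-3-yl and phenyl on the same chain would separate these. Also open, going by these compounds, is whether it persists on a longer chain, or with an amine or a carboxylic acid on the thiophene ring.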